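Lengthening the Sulfur Chain in a Chloromethyl Ketone Series

The source may hold more compounds than are shown below. What is called first, only, known or untested is meant among the compounds shown, and "the series" means these compounds.

Measured so far:
Compound 1 `CSC[C@H](NC(C)=O)C(=O)CCl` gives 80800 nM in a functional assay on MOLT-3 cells (Homo sapiens); a higher number here means a weaker inhibitor, a lower number a stronger inhibitor.
Compound 2 `CCCSC[C@H](NC(C)=O)C(=O)CCl` gives 8000 nM in this assay.

Within the data shown here, of these two numbers, compound 2 has the lower one; its only neighbour is compound 1, and the gap between them is the step of a 10-fold lower number from compound 1 to compound 2 (1.00 log units; beyond the scatter). Compound 3 `CCCCSC[C@H](NC(C)=O)C(=O)CCl` extends the same chain one carbon further, differing from compound 2 by methyl in place of hydrogen on a saturated chain carbon, three bonds along the chain from a sulfur. Among the measured compounds shown here, the single measured step that bears on this change is the earlier extension of the same chain, a 10-fold lower number from compound 1 to compound 2 (1.00 log units; beyond the scatter), which was beyond the scatter. That change put ethyl in place of hydrogen; the new one puts only methyl in place of hydrogen, so a smaller step in the same downward direction is expected, a 2.3-fold lower number from compound 2 to compound 3 (0.36 log units; beyond the scatter). Compound 3 is therefore estimated to give 3500 nM in this assay, with a likely range from 1200 nM to 10000 nM.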

Compound 3, half-maximal inhibitory concentration: 5600 nM
Compound 3: middle estimate off by 1.6-fold (0.20 log units), on the low side; the measured number falls inside the stated range.
By their numbers in this assay, from the lowest: compounds 3 and 2 (each within the scatter of the next); then compound 1.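

The step of a 1.4-fold lower number from compound 2 to compound 3 (0.15 log units; within the scatter) lies within the scatter, so in this assay compound 2 and compound 3 cannot be told apart, and the added methyl, three bonds along the chain from a sulfur, makes no readable difference. Over the whole chain the picture is different: the step of a 14-fold lower number from compound 1 to compound 3 (1.16 log units; beyond the scatter) is beyond the scatter, so both longer chains stand clear of compound 1, while the last carbon adds nothing that can be read. No measurement shown gives a reason for this pattern.

On these data alone, whether a longer chain such as pentyl or hexyl would stay level with compound 3 or move away from it remains open. So does the effect of a phenyl group in place of the butyl chain.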